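Amine Substituent Variation in an Antiproliferative Series

This account rests on a few compounds, and the source may have more. Where it says the series, first, only, none or still open, it means among the compounds named here.

Compound 1, `CC(=O)Oc1ccc(C(=O)Nc2cc3ccc(OCC4CCN(C)C4)c(C)c3oc2=O)cc1CC=C(C)C`: in a functional assay on SK-BR-3 cells (Homo sapiens) for antiproliferative activity (on this read-out higher numbers stand for weaker inhibition and lower numbers for stronger inhibition), compound 1 gives 880 nM
Compound 2, `CC(=O)Oc1ccc(C(=O)Nc2cc3ccc(OCC4CCCNC4)c(C)c3oc2=O)cc1CC=C(C)C`: compound 2 gives 620 nM
Compound 3, `CCNCCCOc1ccc2cc(NC(=O)c3ccc(O)c(CC=C(C)C)c3)c(=O)oc2c1C`: compound 3 gives 720 nM

Among these three numbers compound 3 stands second highest, with compound 2 nearest and compound 1 furthest, both within the scatter of it. Compound 4, `CC(C)=CCc1cc(C(=O)Nc2cc3ccc(OCCCNC(C)(C)C)c(C)c3oc2=O)ccc1O`, differs from compound 3 only at the amine: tert-butyl in place of ethyl on an amine nitrogen. Among the compounds with values here, the one measured step that bears on a change at the amine is a 1.4-fold lower number from compound 1 to compound 2 (0.15 log units; within the scatter), which stayed within the scatter. With no other guidance, the step to compound 4 is expected to be a 1.0-fold lower number from compound 3 to compound 4 (0.01 log units; within the scatter), none beyond the scatter. Compound 4 is therefore estimated at 700 nM in this assay, in a range from 350 nM to 1400 nM.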

Compound 4, half-maximal inhibitory concentration: 660 nM
The estimate for compound 4 lay 1.1-fold (0.03 log units) above the measured number; low and high end bracket the measured number.
By their numbers in this assay, from the lowest: compounds 2, 4, 3 and 1 (each within the scatter of the next).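

In this assay the change from ethyl to tert-butyl on the amine nitrogen gives a 1.1-fold lower number from compound 3 to compound 4 (0.04 log units; within the scatter) for this chain. This position therefore takes a group of 4 heavy atoms in place of one of 2 with no change beyond the scatter, which the earlier step, made at a ring amine, could not show. Nothing measured here accounts for this result. Still open, as far as these compounds go, is whether an unsubstituted amine, a benzyl group on the nitrogen or a carboxylic acid in place of the amine would also stay within the scatter.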